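The compounds below may be only part of what the source reports. "The series", "measured", "known", "first", "only" and "open" are said of these compounds alone.

Measured so far:
compound 1 `[O-]/[N+](=C\c1cn(-c2ccc(F)cc2)nn1)Cc1ccccc1` — in a functional assay on MDA-MB-231 cells (Homo sapiens) for inhibition, read by MTT assay, with a stated time of 24 h (a higher number here means a weaker inhibitor, a lower number a stronger inhibitor), gives > 100000 nM, a limit of the assay rather than a number
compound 2 `CC(C)(C)/[N+]([O-])=C/c1cn(-c2ccccc2)nn1` — in this assay gives 14800 nM

In this assay compound 2 holds the only number shown. For compound 1 the result stands at the limit of > 100000 nM in this assay, at which 1 of the 2 values shown sits, so it sets no number. Compound 3 `CC(C)(C)/[N+]([O-])=C/c1cn(-c2ccc(F)cc2)nn1` differs from compound 2 by fluoro in place of hydrogen on an aromatic carbon. Among the compounds with values here, no step between measured compounds covers this change, so the expected step from compound 2 to compound 3 is taken as a 1.2-fold lower number from compound 2 to compound 3 (0.09 log units; within the scatter), within the usual scatter. Compound 3 is estimated at 12000 nM in this assay, range 4000 nM to 40000 nM.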

Compound 3, half-maximal inhibitory concentration: 66400 nM
Beside the measured number, compound 3's estimate is 5.5-fold (0.74 log units) below it; the measured number lies above the stated range.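

In this assay, fluoro in place of hydrogen on an aromatic carbon, para to a large group, gives a 4.5-fold higher number from compound 2 to compound 3 (0.65 log units; beyond the scatter), so this position responds to the change by more than the scatter. With fluoro held, tert-butyl in place of benzyl on a double-bonded nitrogen gives an at least 1.5-fold lower number from compound 1 to compound 3 (0.17 log units; that floor lies within the scatter), which fixes no size for that change. Compound 1 remains a limit of the assay, not a number: the limit of > 100000 nM in this assay, at which 1 of the 3 values shown sits.

On these data alone, whether chlorine or a methoxy group at this position would read like fluoro remains open. So does the effect of an amine or a carboxylic acid there.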